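The source may hold more compounds than are shown below. What is called first, only, known or untested is meant among the compounds shown, and "the series" means these compounds.

In an ADME assay on BJ cells (Homo sapiens) for cytotoxicity, with a stated time of 72 h (a higher number here means that more compound is needed for the effect, a lower number that less compound is needed), three compounds sharing one core have been measured. Compound 1 `CCc1ccc(-c2nc3c(c(C)nn3-c3ccccc3)c(-c3ccccc3O)c2C#N)cc1` carries hydroxy and gives > 20000 nM as a limit of the assay. Compound 2 `CCc1ccc(-c2nc3c(c(C)nn3-c3ccccc3)c(-c3ccccc3I)c2C#N)cc1` carries iodo in that place and gives > 20000 nM as a limit too. Compound 3 `CCc1ccc(-c2nc3c(c(C)nn3-c3ccccc3)c(-c3ccccc3Cl)c2C#N)cc1` carries chloro there and stands at > 20000 nM as a limit as well. The whole set thus rests at the limit of > 20000 nM in this assay, at which 3 of the 3 values shown sit, and offers no number. The change to compound 4 `CCc1ccc(-c2nc3c(c(C)nn3-c3ccccc3)c(-c3ccccc3C)c2C#N)cc1` is methyl in place of chloro on an aromatic carbon and amounts to methyl in place of chloro on an aromatic carbon, ortho to a large group. Three exchanges at that same place bear on it, namely a step that the two limits leave unreadable from compound 1 to compound 2 and a step that the two limits leave unreadable from compound 1 to compound 3 and finally a step that the two limits leave unreadable from compound 2 to compound 3 in the same series. None of them has a readable size. Hydroxy, iodo and chloro all left their compounds at the limit, and no step beyond the scatter is expected in either direction for methyl. The expected step is a step that the limit leaves unreadable from compound 3 to compound 4 in this estimate. Compound 4 is estimated at 25000 nM with a range from 12000 nM to 50000 nM and is expected to be reported as a limit again.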

Compound 4, half-maximal effective concentration: > 20000 nM
Compound 4: a limit, no number (the forecaster's own chance of this, stated with the estimate: 90%); the middle value is on the limit's open side.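

Compound 4 is again a limit, so its steps from compound 1, compound 2 and compound 3 cannot be read: the limit of > 20000 nM in this assay, at which 4 of the 4 values shown sit. The compounds shown leave open whether hydroxy, iodo, chloro and methyl differ at all in this assay, as none of the four has a number.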